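The source may hold more compounds than are shown below. What is called first, only, known or untested is meant among the compounds shown, and "the series" means these compounds.

Compounds measured so far:
compound 1, `OC[C@H]1O[C@@H](n2cnc3c(NCc4ccc(Cl)cc4)ncnc32)[C@H](O)[C@@H]1O`, 1700 nM
compound 2, `OC[C@H]1O[C@@H](n2cnc3c(NCc4ccc(F)c(F)c4F)ncnc32)[C@H](O)[C@@H]1O`, 13000 nM
compound 3, `OC[C@H]1O[C@@H](n2cnc3c(NCc4ccc(F)cc4Cl)ncnc32)[C@H](O)[C@@H]1O`, 9000 nM

In a functional assay on HL-60 cells (Homo sapiens) for antiproliferative activity, with a stated time of 72 h (on this read-out higher numbers stand for weaker inhibition and lower numbers for stronger inhibition), compound 1 gives the lowest of the three numbers. Its nearest neighbour is compound 3, reached by a 5.3-fold higher number from compound 1 to compound 3 (0.72 log units; beyond the scatter); the furthest is compound 2, reached by a 7.6-fold higher number from compound 1 to compound 2 (0.88 log units; beyond the scatter). Between those two, the step of a 1.4-fold lower number from compound 2 to compound 3 (0.16 log units; within the scatter) separates nothing.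

The unmeasured compound 4, `Cc1cccc(CNc2ncnc3c2ncn3[C@@H]2O[C@H](CO)[C@@H](O)[C@H]2O)c1O`, shares the core of compound 1 and differs from it at one place: 2-hydroxy-3-methylphenyl in place of 4-chlorophenyl on a saturated chain carbon bound to a nitrogen on an aromatic ring.

The two steps that bear on this change both start from compound 1 and both exchange the 4-chlorophenyl for another substituted phenyl: a 7.6-fold higher number from compound 1 to compound 2 (0.88 log units; beyond the scatter) and a 5.3-fold higher number from compound 1 to compound 3 (0.72 log units; beyond the scatter). Both moved the number upward by a modest but clear margin. Neither of those groups carries a hydrogen-bond donor or acceptor, as 2-hydroxy-3-methylphenyl does, so the data give no direct guide for that part of the change. On the evidence that exists, a step in this assay of the same modest size and the same upward direction as those two is expected, with wide uncertainty, so that compound 4 is expected at 7000 nM, in the range 1500 nM to 35000 nM, which means an estimated step of a 4.1-fold higher number from compound 1 to compound 4 (0.61 log units; beyond the scatter).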

Compound 4, half-maximal inhibitory concentration: 15000 nM
Estimate against measurement, compound 4: 2.1-fold (0.33 log units) below, and the stated range covers the measured number.
By their numbers in this assay, from the lowest: compound 1; then compounds 3, 2 and 4 (each within the scatter of the next).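

In this assay the change to 2-hydroxy-3-methylphenyl, which brings a hydrogen-bond donor and acceptor that 4-chlorophenyl lacks, gives an 8.8-fold higher number from compound 1 to compound 4 (0.95 log units; beyond the scatter) and so leaves compound 1 as the strongest of the four, with all three replacements at this position now raising the number beyond the scatter. The new group does not separate itself from the two halogen-bearing replacements, with a 1.7-fold higher number from compound 3 to compound 4 (0.22 log units; within the scatter) and a 1.2-fold higher number from compound 2 to compound 4 (0.06 log units; within the scatter) both falling short of a real difference, so a hydrogen-bond donor and acceptor on this phenyl ring, set against none, shows no gain or loss here, and compounds 2, 3 and 4 sit at one level. Nothing measured alongside these numbers explains this result.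

As far as these compounds go, what remains open is whether the low number of compound 1 goes with its chlorine or with the absence of any further group on the ring, a question that an unsubstituted phenyl, a 4-methylphenyl or a 4-hydroxyphenyl would address. The compounds shown also leave open whether the hydroxyl and the methyl of compound 4 count separately, which 2-hydroxyphenyl and 3-methylphenyl would test.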